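Replacing an ethyl with fluoro on the fused core

The source may report more compounds than this note shows. Statements on the series, on what has been measured and on what is new or still open speak of the compounds shown alone.

Measured so far:
compound 1 `Cc1ccc2nc(C(=O)Nc3c(F)cc(-c4cccc(F)c4)cc3F)c(C)c(O)c2c1`: 0.22%
compound 2 `CCc1ccc2nc(C(=O)Nc3c(F)cc(-c4cccc(F)c4)cc3F)c(C)c(O)c2c1`: 0.74%

Both measured compounds share one core and one amide-linked fluorinated biphenyl part. In a functional assay on Hep 3B2 cells (Homo sapiens) for antiproliferative activity, read by MTT assay, with a stated time of 24 h, tested at 0.01 ug/mL (on this read-out higher numbers stand for a stronger effect at the one concentration tested and lower numbers for a weaker effect), compound 1 gives 0.22%, and compound 2 gives 0.74%. Within the data shown here, the one measured step, a number 0.5 percentage points higher from compound 1 to compound 2 (within the scatter), shows that the two numbers lie within the scatter of each other, so neither compound can be set apart from the other; compound 2 simply stands with compound 1 near the bottom of the scale.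

Compound 3 `Cc1c(C(=O)Nc2c(F)cc(-c3cccc(F)c3)cc2F)nc2ccc(F)cc2c1O` is not yet measured. It differs from compound 2 by fluoro in place of ethyl on an aromatic carbon. Among the measured compounds shown here, the only step seen so far concerns a methyl in place of hydrogen on a saturated chain carbon, a different kind of change at the same region of the core, and that step stayed within the scatter. For the measured compounds named here, no measured step speaks directly to swapping ethyl for fluoro, so there is no ground to expect a movement beyond the scatter in this assay in either direction.

Compound 3 is therefore estimated at 0.6%, within -4% to 8%, an expected step of a number 0.1 percentage points lower from compound 2 to compound 3 (within the scatter).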

Compound 3, a percentage reported as inhibition, at one concentration (the size of the read-out at that concentration, not a potency): -0.12%
For compound 3 the middle estimate is 0.7 percentage points above the measured one; measured number inside the range.
By their numbers in this assay, from the lowest: compounds 3, 1 and 2 (each within the scatter of the next).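

In this assay, fluoro in place of ethyl on this aromatic carbon gives a number 0.9 percentage points lower from compound 2 to compound 3 (within the scatter), and fluoro in place of methyl at the same carbon gives a number 0.3 percentage points lower from compound 1 to compound 3 (within the scatter). Among these compounds, this is the first time the position has carried something other than a small carbon chain, and swapping a saturated carbon group for a single halogen atom still leaves all three compounds indistinguishable, with compound 3 at -0.12% reading essentially as no effect at the one concentration tested. So, among methyl, ethyl and fluoro, the choice of group at this position makes no visible difference on this read-out, although no measurement here offers any explanation for that.

On these data alone, it remains open whether a group of another kind on this carbon, such as an amine or a carboxylic acid, or a longer chain such as butyl, would lift the reading clear of the scatter. As far as these compounds go, it also remains open whether compound 1, compound 2 and compound 3 would separate at a concentration other than the single one used here.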